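Series notes: chloro step from compound 1 to compound 4

This account rests on a few compounds, and the source may have more. Where it says the series, first, only, none or still open, it means among the compounds named here.

Compound 1 `O=C1NC(=O)/C(=C/c2ccccc2OCN2C(=O)c3ccccc3C2=O)S1` gives > 100000 nM in an assay on isolated protein for inhibition of Alpha glucosidase (Homo sapiens), read by spectrophotometry, with stated times of 15 min and 30 min (on this read-out lower numbers stand for stronger inhibition and higher numbers for weaker inhibition), which is a limit of the assay and not a number.
Compound 2 `O=C1NC(=O)/C(=C/c2ccc(OCN3C(=O)c4ccccc4C3=O)cc2)S1` gives 25600 nM in this assay.
Compound 3 `COc1cccc(/C=C2\SC(=O)NC2=O)c1OCN1C(=O)c2ccccc2C1=O` gives > 100000 nM in this assay, again a limit of the assay.

Compound 1 stands only at a limit in this assay; of the three values shown, two sit at the limit of > 100000 nM in this assay, at which 2 of the 3 values shown sit. For the measured compounds named here, compound 2 is the only member with a measured number, and it carries its substituent in a different place, so no step to compound 1 is counted for it.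

Compound 4 `O=C1NC(=O)/C(=C/c2cc(Cl)ccc2OCN2C(=O)c3ccccc3C2=O)S1` arises from compound 1 through (chloro in place of hydrogen on an aromatic carbon). Going by the values given here, the one measured step that starts from compound 1 is a step that the two limits leave unreadable from compound 1 to compound 3; its size cannot be read because both of its ends rest at the limit of > 100000 nM in this assay, at which 2 of the 3 values shown sit. Among the compounds with values here, there is therefore no measured step that shows what a small substituent on this ring does.

The expectation for compound 4 is that it most likely remains at the limit, so the step of a number no higher from compound 1 to compound 4 (the limit leaves the size open) is estimated as none that can be read. Compound 4 is estimated at 100000 nM, with a range from 30000 nM to 300000 nM.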

Compound 4, half-maximal inhibitory concentration: > 100000 nM
Compound 4 ended at the assay's limit; the forecaster's own chance of this, stated with the estimate: 75%; the middle value sits exactly at the limit.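

No step can be read between compound 1 and compound 4, because both rest at a limit of the assay and not at a number: the limit of > 100000 nM in this assay, at which 3 of the 4 values shown sit.

From the compounds shown here alone, what a chloro or methoxy group on the core of compound 1 does to inhibition in this assay stays open.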